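The source may hold more compounds than are shown below. What is called first, only, known or untested is meant among the compounds shown, and "the series" means these compounds.

Measured in a functional assay on FaDu cells (Homo sapiens) for cytotoxicity, read by MTT assay, with a stated time of 72 h; on this read-out higher numbers stand for lower toxicity in this test and lower numbers for higher toxicity in this test:
- compound 1 `COc1ccc(NC(=O)C(=O)c2cn(C(C)C)c3ccccc23)cn1`: 85 nM
- compound 2 `COc1ccc2c(C(=O)C(=O)Nc3ccc(OC)nc3)cn(C(C)C)c2c1`: > 10000 nM
- compound 3 `CC(C)Oc1ccc(NC(=O)C(=O)c2cn(C(C)C)c3ccccc23)cn1`: 408 nM

Compound 1 stands lowest of the numbers, and compound 3 is its nearest neighbour. The entry for compound 2 is a limit of the assay, not a number.

The next compound is compound 4 `COc1ccc(NC(=O)C(=O)c2cn(CC(C)C)c3ccccc23)cn1`, which carries isobutyl in place of isopropyl on an aromatic nitrogen. For the measured compounds named here, no measured step touches that nitrogen, so the evidence is indirect. Methoxy in place of hydrogen on an aromatic carbon gave a large step, an at least 110-fold higher number from compound 1 to compound 2 (2.07 log units; beyond the scatter). That change is unlike this one and offers little guidance. The closer parallel is isopropyl in place of methyl on an oxygen, a modest step, a 4.8-fold higher number from compound 1 to compound 3 (0.68 log units; beyond the scatter). A similarly modest move toward higher numbers in this assay is therefore expected, though it may stay within the scatter, with an estimated 2.0-fold higher number from compound 1 to compound 4 (0.30 log units; within the scatter). For compound 4 the expected value is 170 nM, with an estimated range of 50 nM to 700 nM.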

Compound 4, concentration lethal to 50% of the cells: 317 nM
Beside the measured number, compound 4's estimate is 1.9-fold (0.27 log units) below it; the range from low to high includes it.
By their numbers in this assay, from the lowest: compound 1; then compounds 4 and 3 (each within the scatter of the next). At a limit, above all of these: compound 2.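

With isobutyl in place of isopropyl on the aromatic nitrogen, this assay gives a 3.7-fold higher number from compound 1 to compound 4 (0.57 log units; beyond the scatter). For the compounds shown here, the earlier steps changed other places, so this is the first sign that the number responds to the group on this nitrogen, and a move from 3 heavy atoms to 4 in a ringless chain is enough to carry it beyond the scatter. Among the groups shown at this position, the isopropyl of compound 1 keeps the lower number.

The compounds shown leave open how the number would respond to a shorter chain such as ethyl, a longer chain such as n-pentyl, or a ring such as cyclopropylmethyl on the same nitrogen. They also leave open whether a chain ending in an amine would fit the same trend. Nothing measured here accounts for the step.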